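Amide nitrogen substituents on a shared core: three measured, one pending

A few compounds are considered here, and "the series" means these few. Any claim that something is new, unique, unknown or untested is made for them only; others in the source may bear on it.

The three measured compounds share one core and differ only in the group on an amide-type nitrogen. In a functional assay on U-87MG ATCC cells for inhibition, with U-87 MG (Homo sapiens) as the target, read by MTT assay, with a stated time of 72 h (on this read-out lower numbers stand for stronger inhibition and higher numbers for weaker inhibition), compound 1 `Cc1noc(C)c1-c1cnc(N)c(Oc2ccc(C(=O)NC3CC3)cc2)n1` gives 43300 nM. Compound 2 `Cc1noc(C)c1-c1cnc(N)c(Oc2ccc(C(=O)NC3CCCC3)cc2)n1` gives 57600 nM, and compound 3 `Cc1noc(C)c1-c1cnc(N)c(Oc2ccc(C(=O)Nc3ccccc3Cl)cc2)n1` gives 60500 nM. The steps among them are small: a 1.3-fold higher number from compound 1 to compound 2 (0.12 log units; within the scatter), a 1.4-fold higher number from compound 1 to compound 3 (0.15 log units; within the scatter) and a 1.1-fold higher number from compound 2 to compound 3 (0.02 log units; within the scatter). Compound 3 thus holds the largest of the three numbers, but both of its gaps to the others are within the scatter, so the three cannot be told apart on these data.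

Compound 4 `Cc1noc(C)c1-c1cnc(N)c(Oc2ccc(C(=O)Nc3ncccc3Cl)cc2)n1` differs from compound 3 as follows: 3-chloropyridin-2-yl in place of 2-chlorophenyl on an amide-type nitrogen. All three measured steps exchange the group on this nitrogen and none moved the number beyond the scatter; none, however, exchanges a ring of carbon only for a ring with one hetero atom, so that particular change is without precedent here. On this basis compound 4 is expected to stay close to compound 3, with a 1.0-fold lower number from compound 3 to compound 4 (0.00 log units; within the scatter) foreseen as no step beyond the scatter. Compound 4 is therefore estimated at 60000 nM, within 30000 nM to 120000 nM.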

Compound 4, half-maximal inhibitory concentration: 45600 nM
The estimate for compound 4 lay 1.3-fold (0.12 log units) above the measured number, and the stated range covers the measured number.
By their numbers in this assay, from the lowest: compounds 1, 4, 2 and 3 (each within the scatter of the next).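

Going by these compounds alone, the 3-chloropyridin-2-yl group is the one exchange here of a ring of carbon only for a ring with one hetero atom on this amide-type nitrogen, and in this assay it brings a hydrogen-bond acceptor into the group without a step beyond the scatter (a 1.3-fold lower number from compound 3 to compound 4 (0.12 log units; within the scatter)). Set against the cyclopentyl and cyclopropyl groups, it likewise stays within the scatter (a 1.3-fold lower number from compound 2 to compound 4 (0.10 log units; within the scatter); a 1.1-fold higher number from compound 1 to compound 4 (0.02 log units; within the scatter)), so no exchange among these four groups separates any two compounds. Nothing measured beyond these numbers bears on this result.

Open, as far as these compounds go, is whether a different kind of group on this nitrogen, such as a carboxylic acid, an aminoethyl chain or a longer alkyl chain, would give a step beyond the scatter. A plain pyridin-2-yl group would show whether the chlorine of compound 4 counts at all.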